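The source may hold more compounds than are shown below. What is called first, only, known or untested is meant among the compounds shown, and "the series" means these compounds.

Measured so far in a physicochemical assay for lipophilicity, read by HPLC, measured as chromatographic lipophilicity, at pH 7.4; a higher number here means a more lipophilic compound, a lower number a more polar compound:

- compound 1 `O=C(c1ccccc1)N1CCC(C(=O)N2N=CCC2c2ccccc2)CC1` gives 4.4
- compound 2 `O=C(c1cccnc1)N1CCC(C(=O)N2N=CCC2c2ccccc2)CC1` gives 2.6

Compound 2 holds the lower of the two numbers, and the step separating them is beyond the scatter. Compound 3 `O=C(C1CCN(C(=O)C(F)(F)F)CC1)N1N=CCC1c1ccccc1` has not yet been measured. The change trifluoromethyl in place of pyridin-3-yl on a carbonyl carbon puts trifluoromethyl in place of pyridin-3-yl on a carbonyl carbon. For the measured compounds named here, one measured step bears on this, at the same kind of place: a number 1.80 log units lower from compound 1 to compound 2 (beyond the scatter) is large. Going by the values given here, no measured compound carries trifluoromethyl, so only a partial return upward in this assay is expected. The expected change is a number 0.80 log units higher from compound 2 to compound 3 (beyond the scatter) and it is uncertain in size. For compound 3 the estimate is 3.4 as the expected value, within an estimated range from 2.8 to 4 on this scale.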

Compound 3, distribution coefficient: 4.9
Compound 3: middle estimate off by 1.50 log units, on the low side; measured number above the stated range.
By their numbers in this assay, from the lowest: compound 2; then compound 1; then compound 3.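

In this assay trifluoromethyl on this carbonyl carbon gives a number 2.30 log units higher from compound 2 to compound 3 (beyond the scatter) and also a number 0.50 log units higher from compound 1 to compound 3 (beyond the scatter) at the same place, so it stands above phenyl as well as pyridin-3-yl. The number at this place can therefore move both up and down from that of phenyl, and the highest of the three belongs to the group with no ring. On these data alone, whether a methyl, an amine or a carboxylic acid on this carbonyl carbon would fall within this span stays open. Nothing available explains this order.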